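The compounds below may be only part of what the source reports. "The series", "measured", "known", "first", "only" and "open" are said of these compounds alone.

Working notes on the series. Within the data shown here, in a functional assay on SW480 cells (Homo sapiens) for cytotoxicity, read by MTT assay, with a stated time of 24 h (a higher number here means a weaker inhibitor, a lower number a stronger inhibitor), compound 2 `C=CC1=C(C(=O)NC2CCCCC2)C(c2ccc(OC)c(OC)c2)OC1` gives 19100 nM, the only number among the three measured compounds. Compound 1 `C=CC1=C(C(=O)NCc2ccccc2)C(c2ccc(OC)c(OC)c2)OC1` reaches only a limit of this assay, > 100000 nM. Compound 3 `C=CC1=C(C(=O)NC2CCCCC2)C(c2ccc(OC)cc2)OC1` likewise sits at a limit in this assay, > 100000 nM. Two of the three results thus sit at the limit of > 100000 nM in this assay, at which 2 of the 3 values shown sit. Among the measured compounds shown here, the step of an at least 5.2-fold lower number from compound 1 to compound 2 (0.71 log units; beyond the scatter), cyclohexyl in place of benzyl on the amide nitrogen, is the only measured change at that position; the step of an at least 5.2-fold higher number from compound 2 to compound 3 (0.71 log units; beyond the scatter) concerns the aromatic methoxy and does not bear on the amide substituent.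

Compound 4 `C=CC1=C(C(=O)NCCC)C(c2ccc(OC)c(OC)c2)OC1` differs from compound 2 by propyl in place of cyclohexyl on an amide-type nitrogen. For the measured compounds named here, the one measured step at this nitrogen, an at least 5.2-fold lower number from compound 1 to compound 2 (0.71 log units; beyond the scatter), shows that the amide substituent can move this assay beyond the scatter. Going by the values given here, no measured compound carries an acyclic chain there, so the expectation rests on compound 2 alone, the only compound with a number, 19100 nM. In this assay compound 4 is expected to give 50000 nM, within 15000 nM to 150000 nM. The step of a 2.6-fold higher number from compound 2 to compound 4 (0.42 log units; beyond the scatter) is therefore expected to be an increase, with a real chance that only a limit is reported.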

Compound 4, half-maximal inhibitory concentration: > 100000 nM
Compound 4 was reported as a limit; the forecaster's own chance of this, stated with the estimate: 40%; at least 2.0-fold (0.30 log units) between middle value and limit.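

In this assay, among these compounds, propyl in place of cyclohexyl on the amide-type nitrogen gives an at least 5.2-fold higher number from compound 2 to compound 4 (0.71 log units; beyond the scatter), so cyclohexyl now stands apart from an acyclic chain as well as from benzyl, and compound 2 remains the only compound with a number. The step from compound 1 to compound 4 cannot be read, as both results are limits. The series now rests largely on a single limit: the limit of > 100000 nM in this assay, at which 3 of the 4 values shown sit.

Left open is whether another ring on this nitrogen, such as cyclopentyl or cycloheptyl, or a longer chain such as hexyl, would give a number rather than a limit. Also open, going by these compounds, is how far compound 1, compound 3 and compound 4 lie from one another, since their limits give no order among them.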